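The source may hold more compounds than are shown below. What is called first, only, known or untested is meant among the compounds shown, and "the series" means these compounds.

Measured so far:
compound 1 `O=C(Nc1ccc(Oc2ccnc3[nH]ccc23)cc1)c1nn(-c2ccc(Cl)c(F)c2)ccc1=O` — 7780 nM
compound 2 `O=C(Nc1ccc(Oc2ccnc3[nH]ccc23)cc1)c1nn(-c2ccc(Cl)c(C(F)(F)F)c2)ccc1=O` — 4630 nM

In a functional assay on PC-3 cells (Homo sapiens) for cytotoxicity, read by MTT assay, with a stated time of 72 h (on this read-out lower numbers stand for stronger inhibition and higher numbers for weaker inhibition), compound 2 stands at the lower of the two numbers, although the step of a 1.7-fold lower number from compound 1 to compound 2 (0.23 log units; within the scatter) is within the scatter. Compound 3 `O=C(Nc1ccc(Oc2ccnc3[nH]ccc23)c(F)c1)c1nn(-c2ccc(Cl)c(C(F)(F)F)c2)ccc1=O` differs from compound 2 by fluoro in place of hydrogen on an aromatic carbon. Among the measured compounds shown here, no measured step touches this position; the one step measured, a 1.7-fold lower number from compound 1 to compound 2 (0.23 log units; within the scatter), concerns a different change, so nothing here points to a shift beyond the scatter. For compound 3 the expected step is a 1.2-fold lower number from compound 2 to compound 3 (0.06 log units; within the scatter), a small one. Compound 3 is therefore estimated at 4000 nM, with a range from 1500 nM to 10000 nM.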

Compound 3, half-maximal inhibitory concentration: 5500 nM
Estimate against measurement, compound 3: 1.4-fold (0.14 log units) below; the range from low to high includes it.
By their numbers in this assay, from the lowest: compounds 2, 3 and 1 (each within the scatter of the next).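

Fluoro in place of hydrogen on this aromatic carbon, ortho to a large group and meta to a large group, gives a 1.2-fold higher number from compound 2 to compound 3 (0.07 log units; within the scatter) in this assay. Among the compounds shown here, this is the first reading at this position, and it does not separate the compound with fluoro from the one with hydrogen. No measurement shown here offers an explanation for this result. From the compounds shown here alone, whether a larger change here, such as an amine or a methoxy group, would move the number beyond the scatter remains open. One small atom at one position cannot show how much this carbon matters.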